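The source may report more compounds than this note shows. Statements on the series, on what has been measured and on what is new or still open speak of the compounds shown alone.

Measured in a functional assay for inhibition, with Homo sapiens as the target; a higher number here means that more compound is needed for the effect, a lower number that less compound is needed:
- compound 1 `CC(=O)Nc1ccc(C2=NNC(=O)CC2)cc1`: 1 ug/mL
- compound 2 `CC(Cl)C(=O)Nc1ccc(C2=NNC(=O)CC2)cc1`: 0.45 ug/mL

Of these two compounds, compound 2 has the lower number, 0.45 ug/mL, and so needs less compound for the effect. The next compound, compound 3 `O=C1CCC(c2ccc(NC(=O)CCCl)cc2)=NN1`, has not yet been measured. It has the same atoms as compound 2, joined differently: 2-chloroethyl in place of 1-chloroethyl on a carbonyl carbon. Among the compounds with values here, only one measured step bears on this change: a 2.2-fold lower number from compound 1 to compound 2 (0.35 log units; beyond the scatter). Within the data shown here, that modest step put 1-chloroethyl in place of methyl on a carbonyl carbon, and no measured step compares 1-chloroethyl with 2-chloroethyl. Among the measured compounds shown here, a change no larger than that step is therefore expected in this assay, with at most a slight drift back towards compound 1 and a direction that remains uncertain. The expected change is a 1.3-fold higher number from compound 2 to compound 3 (0.12 log units; within the scatter). For compound 3 the estimated value is 0.6 ug/mL, with an expected range of 0.2 ug/mL to 1.5 ug/mL.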

Compound 3, half-maximal effective concentration: 0.98 ug/mL
For compound 3 the middle estimate is 1.6-fold (0.21 log units) below the measured one; the measured number falls inside the stated range.
By their numbers in this assay, from the lowest: compound 2; then compounds 3 and 1 (each within the scatter of the next).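

In this assay, the two chloroethyl groups are not interchangeable: 2-chloroethyl in place of 1-chloroethyl on a carbonyl carbon gives a clear shift (a 2.2-fold higher number from compound 2 to compound 3 (0.34 log units; beyond the scatter)), so the step seen earlier belongs to 1-chloroethyl specifically and not to any chloroethyl group on this carbonyl carbon. Chloromethyl in place of hydrogen on the saturated chain carbon bound to the carbonyl carbon gives no change beyond the scatter (a 1.0-fold lower number from compound 1 to compound 3 (0.01 log units; within the scatter)), which leaves 2-chloroethyl and the methyl of the first compound indistinguishable here. Of the three compounds, only compound 2 stands apart from the others.

Going by these compounds, whether chlorine is needed at all remains open, since plain ethyl, 1-bromoethyl or 1-hydroxyethyl on this carbonyl carbon would test that. Nothing given here offers an explanation for the difference between the two chloroethyl groups.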